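The source may hold more compounds than are shown below. What is called first, only, known or untested is meant among the compounds shown, and "the series" means these compounds.

In an ADME assay on cells (Fibroblast, Homo sapiens) for inhibition, read by MTT assay, with a stated time of 24 h (on this read-out lower numbers stand for stronger inhibition and higher numbers for weaker inhibition), two compounds sharing one core have been read so far. Compound 1 (`CCCCOc1ccc(C(=O)N/N=C/c2ccc3c(c2)no[n+]3[O-])cc1`), which carries butoxy, gives > 200000 nM, a limit of the assay and not a number. Compound 2 (`O=C(N/N=C/c1ccc2c(c1)no[n+]2[O-])c1ccc(I)cc1`), which carries iodo in that place, gives > 200000 nM, again only a limit. Compound 2 therefore offers no measured number as a starting point, and the whole record so far is the limit of > 200000 nM in this assay, at which 2 of the 2 values shown sit.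

Compound 3 (`NS(=O)(=O)c1ccc(C(=O)N/N=C/c2ccc3c(c2)no[n+]3[O-])cc1`) keeps the core of compound 2 and changes one group: sulfamoyl in place of iodo on an aromatic carbon. Sulfamoyl thus takes the place of iodo on the aromatic carbon, para to a large group. Within the data shown here, the only measured step that bears on this change is a step that the two limits leave unreadable from compound 1 to compound 2, and it gives no size to carry over. Given that step, no change beyond the scatter is expected in this assay, and no direction can be argued. The expected step is a number no higher from compound 2 to compound 3 (the limit leaves the size open), and it may well go unreadable if another limit is reported. For compound 3 the estimate is 200000 nM, with an expected range from 80000 nM to 400000 nM.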

Compound 3, half-maximal inhibitory concentration: 60000 nM
Compound 3: middle estimate off by 3.3-fold (0.52 log units), on the high side; the whole stated range lies above it.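

Sulfamoyl is the first group at this position to bring a number into this assay, which shows that a change on this aromatic carbon, para to a large group, can move the read-out. Set in place of iodo, it gives an at least 3.3-fold lower number from compound 2 to compound 3 (0.52 log units; beyond the scatter), and set in place of butoxy, it gives an at least 3.3-fold lower number from compound 1 to compound 3 (0.52 log units; beyond the scatter). Compound 1 and compound 2 remain limits of the assay and not numbers, so the step between them cannot be read and the full size of both new steps stays unknown: the limit of > 200000 nM in this assay, at which 2 of the 3 values shown sit.

The compounds shown leave open whether this lower number belongs to sulfamoyl in particular, or whether a carboxylic acid, an amine or a methylsulfonyl group on the same carbon would give a similar read-out. They also leave open how an N-methyl sulfamoyl group would compare with compound 3, and so whether the free sulfamoyl group is needed for the number seen here.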